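Swapping the aryl group on the triazole of compound 1

This account rests on a few compounds, and the source may have more. Where it says the series, first, only, none or still open, it means among the compounds named here.

Measured so far:
- compound 1 `COc1ccccc1-c1cn(-c2ccc(O)c(C(=O)Nc3cccc(C(F)(F)F)c3)c2)nn1`: 61%
- compound 2 `COC(=O)c1cc(-n2cc(-c3cccc(O)c3)nn2)ccc1O`: 6%
- compound 3 `COC(=O)c1cc(-n2cc(-c3cc(O)ccc3O)nn2)ccc1O`: 15%

In a functional assay on HCT-116 cells (Homo sapiens) for inhibition, read by MTT assay, with a stated time of 2 days, tested at 10 uM (a lower number here means less inhibition, a higher number more inhibition at the concentration tested (going by the name of the read-out)), compound 1 gives 61%, the highest of the three numbers, and its distance to both compound 3 and compound 2 lies beyond the usual scatter. Among the measured compounds shown here, compound 2 and compound 3 share a methyl ester on the shared core instead of the amide of compound 1, and both carry a hydroxyphenyl on the triazole; the only measured step between them, a number 9 percentage points higher from compound 2 to compound 3 (within the scatter), concerns a hydroxy added to that aryl group and stays within the scatter.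

The unmeasured compound 4 `O=C(Nc1cccc(C(F)(F)F)c1)c1cc(-n2cc(-c3cccc(O)c3)nn2)ccc1O` keeps the amide of compound 1 and changes only the aryl group on the triazole: 3-hydroxyphenyl in place of 2-methoxyphenyl on an aromatic carbon. For the measured compounds named here, no measured step covers this change directly, since neither compound 2 nor compound 3 carries the amide, and no compound pairs a 2-methoxyphenyl with the ester. The low values of compound 2 and compound 3 therefore cannot be separated into the part owed to the ester and the part owed to the aryl group. A modest drop is expected, a number 16 percentage points lower from compound 1 to compound 4 (beyond the scatter), with wide uncertainty. Compound 4 is estimated at 45%, within 15% to 70%.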

Compound 4, a percentage reported as inhibition, at one concentration (the size of the read-out at that concentration, not a potency): 25%
Compound 4: middle estimate off by 20 percentage points, on the high side; low and high end bracket the measured number.
By their numbers in this assay, from the lowest: compounds 2, 3 and 4 (each within the scatter of the next, the first and the last beyond it); then compound 1.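

In this assay, among the compounds shown here, the aryl group on the aromatic carbon of the five-membered ring with 3 nitrogen matters with the amide held fixed: 3-hydroxyphenyl in place of 2-methoxyphenyl gives a number 36 percentage points lower from compound 1 to compound 4 (beyond the scatter), a size of change that the earlier compounds could not reveal, as neither of them carries the amide. Compound 2 and compound 4 share the 3-hydroxyphenyl and differ only in the methyl ester against the amide, and compound 2 gives 6% while compound 4 gives 25%, a gap beyond the scatter, so the amide side of the molecule counts as well. Nothing measured on these compounds gives a cause for the step from the methoxy to the hydroxy compound.

This change alters both the oxygen-bearing group and where it sits on the phenyl ring, and a 3-methoxyphenyl or a 2-hydroxyphenyl on the same amide would be needed to pull those two apart. Also open, going by these compounds, is how a plain phenyl or an aminophenyl would fare at this carbon, and how 2-methoxyphenyl would fare alongside the methyl ester.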